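Two Fused Rings in Place of the Methylcyclohexyl Acid

The compounds below may be only part of what the source reports. "The series", "measured", "known", "first", "only" and "open" are said of these compounds alone.

Compound 1 `C[C@]1(C(=O)O)CC[C@H](C(=O)N2CC[C@](c3ccc(C(F)(C(F)(F)F)C(F)(F)F)cc3)(S(=O)(=O)c3ccc(F)cc3)C2)CC1` is the starting point. In an ADME assay on microsomes from liver (Homo sapiens) for metabolic stability, with a stated time of 10 min (a lower number here means that less of the compound is left, a higher number that more of the compound is left), compound 1 gives 97%, the highest of the three numbers shown here. Compound 2 `C[C@]1(C(=O)N2CC[C@](c3ccc(C(F)(C(F)(F)F)C(F)(F)F)cc3)(S(=O)(=O)c3ccc(F)cc3)C2)CC[C@H](C(=O)O)CC1` gives 80% in this assay, and compound 3 `C[C@]1(C(=O)N2CC[C@](c3ccc(C(F)(C(F)(F)F)C(F)(F)F)cc3)(S(=O)(=O)c3ccc(F)cc3)C2)CC[C@@H](C(=O)O)CC1` gives 85%. Both carry 4-carboxy-1-methylcyclohexyl in place of 4-carboxy-4-methylcyclohexyl on a carbonyl carbon; the step of a number 17 percentage points lower from compound 1 to compound 2 (beyond the scatter) and the step of a number 12 percentage points lower from compound 1 to compound 3 (beyond the scatter) are each modest. The step of a number 5 percentage points higher from compound 2 to compound 3 (within the scatter) lies within the scatter, which fits (the fact that compounds 2 and 3 differ only in the configuration as drawn).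

Compound 4 `O=C(O)C12CCC(C(=O)N3CC[C@](c4ccc(C(F)(C(F)(F)F)C(F)(F)F)cc4)(S(=O)(=O)c4ccc(F)cc4)C3)(CC1)CC2` has not yet been measured. It differs from compound 1 in a group of 11 heavy atoms (9 carbon, 2 oxygen; 2 six-membered non-aromatic rings of carbon only) in place of a group of 10 heavy atoms (8 carbon, 2 oxygen; one six-membered non-aromatic ring of carbon only), on a carbonyl carbon. Within the data shown here, no measured step tests the entry of a group with two six-membered non-aromatic rings of carbon only; the two measured steps show only that moving the carboxy and methyl groups around the single ring costs a modest amount. The number for compound 4 in this assay is therefore expected to stay close to that of compound 1, with the step of a number 7 percentage points lower from compound 1 to compound 4 (within the scatter) expected to lie within or just beyond the scatter. Compound 4 is estimated at 90%, in the range 75% to 99%.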

Compound 4, percent of the compound remaining: 100%
Compound 4: the middle estimate sits 10 percentage points below what was measured; the measured number lies above the stated range.
By their numbers in this assay, from the lowest: compounds 2 and 3 (each within the scatter of the next); then compounds 1 and 4 (each within the scatter of the next).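

Putting the group with 2 six-membered non-aromatic rings of carbon only on the carbonyl carbon gives a number 3 percentage points higher from compound 1 to compound 4 (within the scatter) in this assay, so a second ring at this place, in this one compound, leaves no change that the read-out can separate from scatter. Against the two compounds carrying 4-carboxy-1-methylcyclohexyl, the same swap gives a number 15 percentage points higher from compound 3 to compound 4 (beyond the scatter) and a number 20 percentage points higher from compound 2 to compound 4 (beyond the scatter), so compound 4 keeps the standing of compound 1 over both. Nothing measured here explains why the two-ring group behaves this way.

Among these compounds, only one two-ring group appears, and always with a carboxylic acid on it. From the compounds shown here alone, what a primary amide or a hydroxymethyl group in place of that acid would give, in this assay, stays open, as does whether a two-ring group carrying a methyl group would behave like compound 4.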